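The compounds below may be only part of what the source reports. "The series", "measured", "known", "first", "only" and "open" are said of these compounds alone.

Compound 1 `COc1ccccc1NC(=S)N/N=C/c1ccc2ccccc2n1`: 91700 nM in a functional assay on HL-60 cells (Homo sapiens) for antiproliferative activity, read by sulforhodamine B assay, with a stated time of 72 h; on this read-out lower numbers stand for stronger inhibition and higher numbers for weaker inhibition
Compound 2 `CN(C)C(=S)N/N=C/c1ccc2ccccc2n1`: 50 nM
Compound 3 `S=C(N/N=C/c1ccc2ccccc2n1)Nc1ccc(Br)cc1`: 27500 nM

Compound 1 gives the highest number of the three in this assay; compound 3 comes nearest to it, and compound 2 lies furthest away. Compound 4 `S=C(N/N=C/c1ccc2ccccc2n1)Nc1ccccc1` differs from compound 1 by hydrogen in place of methoxy on an aromatic carbon. Going by the values given here, the only measured step touching the group on the amide-type nitrogen is a 3.3-fold lower number from compound 1 to compound 3 (0.52 log units; beyond the scatter), which exchanged one substituted phenyl for another. Among the compounds with values here, no step in the set removes a methoxy alone, so the expectation rests on that neighbouring change, and on compound 1 and compound 3 both sitting far from compound 2. Compound 4 is therefore expected to stay in the weak range, with an estimated step of a 2.3-fold lower number from compound 1 to compound 4 (0.36 log units; beyond the scatter) toward a somewhat lower number. The estimate for compound 4 is 40000 nM, within 12000 nM to 130000 nM.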

Compound 4, half-maximal inhibitory concentration: 9130 nM
Estimate against measurement, compound 4: 4.4-fold (0.64 log units) above, and the stated range ends above it.
By their numbers in this assay, from the lowest: compound 2; then compound 4; then compound 3; then compound 1.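

In this assay hydrogen gives a 10-fold lower number from compound 1 to compound 4 (1.00 log units; beyond the scatter) in place of methoxy and a 3.0-fold lower number from compound 3 to compound 4 (0.48 log units; beyond the scatter) in place of bromo, so among these three compounds the plain phenyl carries the lowest number and both substituents go with higher ones. Yet anilino still gives a 180-fold higher number from compound 2 to compound 4 (2.26 log units; beyond the scatter) in place of dimethylamino, a far larger step than either change on the phenyl. Nothing given here accounts for these steps. On these data alone, whether a methyl or a chlorine on the phenyl would follow the same direction stays open. So does how a diethylamino group or a piperidine would compare with dimethylamino.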